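Phenyl to 4-Chlorophenyl: Estimate for Compound 3

This account rests on a few compounds, and the source may have more. Where it says the series, first, only, none or still open, it means among the compounds named here.

Compound 2 `Nc1scc(-c2ccc([N+](=O)[O-])cc2)c1C(=O)c1ccccc1` gives 50% in a functional assay on CHO cells for agonist activity at adenosine receptor A1 (Homo sapiens), read by fluorescence and ERK phosphorylation, with stated times of 30 min and 1.5 h, tested at 3 uM; a lower number here means a weaker effect, a higher number a stronger effect of the compound at the concentration tested. Among the measured compounds shown here, the only other measured member, compound 1 `Nc1scc(-c2ccc(Br)cc2)c1C(=O)c1ccccc1`, gives 46% in this assay, and the step of a number 4 percentage points higher from compound 1 to compound 2 (within the scatter) lies within the scatter, so compound 2 stands level with compound 1 on this read-out rather than apart from it.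

Compound 3 `Nc1scc(-c2ccc([N+](=O)[O-])cc2)c1C(=O)c1ccc(Cl)cc1` is not yet measured. It differs from compound 2 by chloro in place of hydrogen on an aromatic carbon. For the measured compounds named here, no measured step bears directly on this change: the single recorded step, a number 4 percentage points higher from compound 1 to compound 2 (within the scatter), exchanges bromo for nitro on an aromatic carbon, not hydrogen for chloro, and it stayed within the scatter. The series therefore offers no ground on which a step beyond the scatter would be expected in either direction in this assay. The expectation is a number close to that of compound 2, which amounts to an estimated step of no change at the digits printed from compound 2 to compound 3 (within the scatter). Compound 3 is estimated at 50%, with a range from 35% to 65%.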

Compound 3, a percentage reported as activity, at one concentration (the size of the read-out at that concentration, not a potency): 47%
For compound 3 the middle estimate is 3 percentage points above the measured one; measured number inside the range.
By their numbers in this assay, from the lowest: compounds 1, 3 and 2 (each within the scatter of the next).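

Among the compounds shown here, the step of a number 3 percentage points lower from compound 2 to compound 3 (within the scatter) is the first reading at this position, since the step of a number 4 percentage points higher from compound 1 to compound 2 (within the scatter) concerned bromo and nitro at a different place on the core. In this assay, phenyl to 4-chlorophenyl, with chloro on an aromatic carbon of a six-membered aromatic ring of carbon only and para to a large group, therefore leaves the read-out level with that of compound 2, which shows that this position accepts one chlorine without a change beyond the scatter, at least with nitro kept in the shared core. No supporting measurement is available to account for this outcome.

On these data alone, whether an amine, a carboxylic acid or a longer chain in place of chloro at this position would move the read-out beyond the scatter remains open, as does the effect of placing chloro elsewhere on the same ring. The read-out is also the size of the effect at a single concentration, so the compounds shown leave open whether potency at the receptor shifts with this change.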